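A few compounds are considered here, and "the series" means these few. Any claim that something is new, unique, unknown or untested is made for them only; others in the source may bear on it.

Measured compounds:
- compound 1, `CCCCc1nc(=O)c(S(=O)(=O)c2ccc(-c3ccc(F)cc3)cc2)c(O)n1-c1c(OC)cccc1OC`, 132 nm/s
- compound 2, `CCCCc1[nH]c(=O)c(S(=O)(=O)c2ccc(-c3ccc(F)nc3)cc2)c(O)c1-c1c(OC)cccc1OC`, "not determined" (no result reported)
- compound 3, `COc1cccc(OC)c1-n1c(CCC(C)C)nc(=O)c(S(=O)(=O)c2ccc(-c3ccc(F)nc3)cc2)c1O`, 35 nm/s

In an ADME assay for permeability, using PAMPA, at pH 7.4 (a lower number here means that the compound crosses the layer more slowly, a higher number that the compound crosses the layer faster), compound 1 gives 132 nm/s, the highest of the two numbers in this set; compound 3 gives 35 nm/s, a lower number that lies beyond the usual scatter. For compound 2 no number is available in this assay.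

Compound 4, `CCCCc1nc(=O)c(S(=O)(=O)c2ccc(C)cc2)c(O)n1-c1c(OC)cccc1OC`, is the next compound. It differs from compound 1 in one place: methyl in place of 4-fluorophenyl on an aromatic carbon. Among the compounds with values here, no step between measured compounds covers this kind of change, so the expectation rests on compound 1 alone. A step somewhat downward, but of modest size, is expected from compound 1 to compound 4 in this assay, a 1.7-fold lower number from compound 1 to compound 4 (0.22 log units; within the scatter). Compound 4 is therefore estimated at 80 nm/s, with a range from 30 nm/s to 250 nm/s.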

Compound 4, apparent permeability: 7 nm/s
Beside the measured number, compound 4's estimate is 11-fold (1.06 log units) above it; measured number below the stated range.
By their numbers in this assay, from the lowest: compound 4; then compound 3; then compound 1.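

Placing methyl instead of 4-fluorophenyl on the aromatic carbon para to a large group gives a 19-fold lower number from compound 1 to compound 4 (1.28 log units; beyond the scatter) in this assay. Within the data shown here, this is the first step in the set that can be read at a single place, and it shows that the number depends strongly on the group held there. Nothing at hand gives a reason for this step. Still open, from the compounds shown here alone, is whether an unsubstituted phenyl, a chlorophenyl or a morpholine at this position would stand nearer compound 1 or compound 4. That leaves unsettled whether the ring or its fluorine goes with the step.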